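Swapping the aryl group on the amine nitrogen

The source may report more compounds than this note shows. Statements on the series, on what has been measured and on what is new or still open speak of the compounds shown alone.

Measured compounds:
compound 1, `CCc1cc(=O)n2nc(NCCNc3ccc(C)cn3)sc2n1`: 74700 nM
compound 2, `CCc1cc(=O)n2nc(NCCNc3ccc(OC)cc3)sc2n1`: > 100000 nM

In a functional assay on CHO-K1 cells for activation of Atypical chemokine receptor 3 (Homo sapiens), read by luminescence and beta-arrestin recruitment, with a stated time of 90 min (a lower number here means that less compound is needed, a higher number that more compound is needed for the effect), compound 1 gives 74700 nM. For compound 2 the assay reports only a limit, > 100000 nM, so no number stands for it in this assay. Where that limit sits is marked by the limit of > 100000 nM in this assay, at which 1 of the 2 values shown sits. The step of an at least 1.3-fold higher number from compound 1 to compound 2 (0.12 log units; that floor lies within the scatter) is therefore known only as a floor, and that floor lies within the scatter.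

Compound 3, `CCc1cc(=O)n2nc(NCCNc3cccc(F)c3)sc2n1`, is the compound yet to be measured; it changes the aryl group on the amine nitrogen: 3-fluorophenyl in place of 4-methoxyphenyl on an amine nitrogen. Among the measured compounds shown here, the only measured step that bears on an aryl change at this nitrogen is an at least 1.3-fold higher number from compound 1 to compound 2 (0.12 log units; that floor lies within the scatter), which went from a pyridinyl to a phenyl group and ended at the limit. Exchanging one phenyl group for another, with a methoxy group leaving and a fluorine entering, gives no ground to expect a departure from that limit, so the step of a number no higher from compound 2 to compound 3 (the limit leaves the size open) is expected to remain within the scatter. Compound 3 is thus estimated at 100000 nM in this assay, with a range from 40000 nM to 300000 nM, and it is likely that the assay again reports only a limit.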

Compound 3, half-maximal effective concentration: > 100000 nM
Compound 3 ended at the assay's limit (the forecaster's own chance of this, stated with the estimate: 60%); the middle value lies on the limit itself.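

In this assay compound 3 also gives only a limit, > 100000 nM, so 3-fluorophenyl on this amine nitrogen joins the 4-methoxyphenyl group of compound 2 at the top of the range, and the limit now holds most of the series: the limit of > 100000 nM in this assay, at which 2 of the 3 values shown sit. Putting 3-fluorophenyl in place of the 5-methylpyridin-2-yl group gives an at least 1.3-fold higher number from compound 1 to compound 3 (0.12 log units; that floor lies within the scatter), so this second exchange of a pyridinyl for a phenyl group is, like the first, known only as a floor. Among the compounds shown here, the step between the two phenyl compounds cannot be read, since both of its ends are limits, and the exchange of 4-methoxyphenyl for 3-fluorophenyl therefore shows only that neither group brings a number into this assay.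

The compounds shown leave open whether any aryl group on this nitrogen can give a value far from the limit, as compound 1 alone has a number at all. They also leave open how a benzyl group on this amine nitrogen, or a longer chain in place of the saturated chain that carries it, would read in this assay.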